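Series notes: the step from compound 2 to compound 3

The compounds below may be only part of what the source reports. "The series", "measured", "known", "first", "only" and "open" are said of these compounds alone.

Measured so far:
compound 1, `CN(C(=O)NC(=O)c1ccc(Cl)cc1Cl)c1nc(C(F)(F)F)c(C(=O)N/N=C/c2cccc(C(F)(F)F)c2)s1`, gives 6.11 ug/mL in a functional assay on BCG823 cells (Homo sapiens) for inhibition, read by MTT assay, with a stated time of 72 h; on this read-out lower numbers stand for stronger inhibition and higher numbers for weaker inhibition
compound 2, `CN(C(=O)NC(=O)c1ccc(F)c(F)c1)c1nc(C(F)(F)F)c(C(=O)N/N=C/c2cc(C(F)(F)F)cc(C(F)(F)F)c2)s1`, gives 3.51 ug/mL in this assay

Compound 2 gives the lowest of the two numbers; its nearest neighbour is compound 1, whose number is higher by a gap that lies within the scatter, so no order between the two is claimed. Among the measured compounds shown here, compound 1 and compound 2 differ in two places, so no single step between them is available.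

Compound 3, `CN(C(=O)NC(=O)c1ccc(Cl)cc1Cl)c1nc(C(F)(F)F)c(C(=O)N/N=C/c2cc(C(F)(F)F)cc(C(F)(F)F)c2)s1`, remains to be measured in this assay. It arises from compound 2 through (2,4-dichlorophenyl in place of 3,4-difluorophenyl on a carbonyl carbon). The same 2,4-dichlorophenyl already stands in compound 1, which gives 6.11 ug/mL. For the measured compounds named here, with no recorded step of this kind, the expected move from compound 2 to compound 3 is a 1.3-fold higher number from compound 2 to compound 3 (0.11 log units; within the scatter), a change not expected to exceed the scatter, with no direction favoured. Compound 3 is estimated at 4.5 ug/mL, within 2 ug/mL to 10 ug/mL.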

Compound 3, half-maximal inhibitory concentration: > 100 ug/mL
Compound 3 was reported as a limit (the forecaster's own chance of this, stated with the estimate: 5%); at least 22-fold (1.34 log units) between middle value and limit.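

Compound 3 is reported only as a limit in this assay: the limit of > 100 ug/mL in this assay, at which 1 of the 3 values shown sits.

On a carbonyl carbon, 2,4-dichlorophenyl in place of 3,4-difluorophenyl is not a neutral exchange, as the step shows an at least 28-fold higher number from compound 2 to compound 3 (1.45 log units; beyond the scatter). Trifluoromethyl in place of hydrogen on an aromatic carbon also proves a large change when 2,4-dichlorophenyl is present, giving an at least 16-fold higher number from compound 1 to compound 3 (1.21 log units; beyond the scatter), so the outcome at one place depends on the group at the other among these compounds.

Still open, on these data alone, is how 3,4-difluorophenyl would read without the added trifluoromethyl, which would show whether that change is large with this group as well. Also open is whether a pyridyl or a 4-methoxyphenyl on the same carbonyl carbon would keep a measurable number alongside the added trifluoromethyl, and the compounds shown give no reason for the change.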